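Replacing 3-nitrophenyl with 4-cyanophenyl: an expected modest shift

The compounds below may be only part of what the source reports. "The series", "measured", "known", "first", "only" and "open" are said of these compounds alone.

Compound 1 `C[C@H]1CC[C@@H]2[C@@H](OC(=O)[C@]23CC(c2ccccc2F)=NO3)[C@]2(C)C(=O)C=C[C@@]12O`: 11000 nM
Compound 2 `C[C@H]1CC[C@@H]2[C@@H](OC(=O)[C@]23CC(c2cccc([N+](=O)[O-])c2)=NO3)[C@]2(C)C(=O)C=C[C@@]12O`: 49000 nM

In a functional assay on SW-620 cells (Homo sapiens) for cytotoxicity, read by sulforhodamine B assay, with a stated time of 48 h (a lower number here means a stronger inhibitor, a higher number a weaker inhibitor), compound 2 at 49000 nM holds the higher of the two numbers, making it the weaker inhibitor of the pair. Compound 3 `C[C@H]1CC[C@@H]2[C@@H](OC(=O)[C@]23CC(c2ccc(C#N)cc2)=NO3)[C@]2(C)C(=O)C=C[C@@]12O` differs from it in one place, where 4-cyanophenyl in place of 3-nitrophenyl on a carbon with a double bond to nitrogen is the change. For the measured compounds named here, the one measured step at this place is a 4.5-fold higher number from compound 1 to compound 2 (0.65 log units; beyond the scatter) and it is modest. Going by the values given here, a step of similar or smaller size is therefore expected, more likely downward since compound 2 at 49000 nM is the top number so far. In this assay the expected change is a 2.2-fold lower number from compound 2 to compound 3 (0.35 log units; beyond the scatter) as an estimate. For compound 3 the estimated value is 22000 nM with a range from 7000 nM to 60000 nM expected.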

Compound 3, half-maximal inhibitory concentration: 53000 nM
Beside the measured number, compound 3's estimate is 2.4-fold (0.38 log units) below it, and the stated range covers the measured number.
By their numbers in this assay, from the lowest: compound 1; then compounds 2 and 3 (each within the scatter of the next).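

4-Cyanophenyl in place of 3-nitrophenyl leaves the reading in this assay unchanged within the scatter (a 1.1-fold higher number from compound 2 to compound 3 (0.03 log units; within the scatter)), so these two different substituted phenyl groups cannot be told apart at this position. 4-Cyanophenyl in place of 2-fluorophenyl gives a clear step (a 4.8-fold higher number from compound 1 to compound 3 (0.68 log units; beyond the scatter)), which leaves the 2-fluorophenyl compound apart from the other two. No supporting data are available to explain this. Still open, on these data alone, is whether an amine or a carboxylic acid on the phenyl ring would shift the number, and whether a simple unsubstituted phenyl or a longer alkyl chain at this carbon would read closer to compound 1 or to compound 3.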